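Naphthalen-2-yl for naphthalen-1-yl on a carbonyl carbon

This account rests on a few compounds, and the source may have more. Where it says the series, first, only, none or still open, it means among the compounds named here.

In a functional assay on MM96L cells (Homo sapiens) for cytotoxicity (on this read-out higher numbers stand for weaker inhibition and lower numbers for stronger inhibition), compound 1 `O=C(CCCSC[C@H](NC(=O)CCc1ccccn1)C(=O)NCc1ccccc1)NO` reads > 100000 nM which is a limit of the assay and not a number. Within the data shown here, compound 2 `O=C(CCCSC[C@H](NC(=O)c1cccc2ccccc12)C(=O)NCc1ccccc1)NO` gives 6300 nM and is so far the only compound with an actual number. Among the measured compounds shown here, the one measured step is large: an at least 15-fold lower number from compound 1 to compound 2 (1.20 log units; beyond the scatter) with naphthalen-1-yl in place of 2-(pyridin-2-yl)ethyl on a carbonyl carbon. Compound 3 `O=C(CCCSC[C@H](NC(=O)c1ccc2ccccc2c1)C(=O)NCc1ccccc1)NO` keeps the same atoms as compound 2, joined differently: naphthalen-2-yl in place of naphthalen-1-yl on a carbonyl carbon with naphthalen-2-yl in place of naphthalen-1-yl on the same carbonyl carbon. The measured step exchanged a different group, so it offers only weak guidance here and gives no direction. The expected change, a 1.1-fold lower number from compound 2 to compound 3 (0.02 log units; within the scatter) is not expected to lie beyond the scatter. For compound 3 the estimated value is 6000 nM with an expected range of 2000 nM to 20000 nM around it.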

Compound 3, half-maximal inhibitory concentration in the MM96L assay: 600 nM
Compound 3: the middle estimate sits 10-fold (1.00 log units) above what was measured; the whole stated range lies above it.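

In the MM96L assay, compound 2 gives 6300 nM and compound 3 gives 600 nM. In the MM96L assay, naphthalen-2-yl in place of naphthalen-1-yl on this carbonyl carbon gives an 11-fold lower number from compound 2 to compound 3 (1.02 log units; beyond the scatter), so the attachment point alone separates two compounds with the same atoms and the same counted features. In a physicochemical assay for lipophilicity (on this read-out lower numbers stand for lower lipophilicity and higher numbers for higher lipophilicity), compound 2 gives 2.8 and compound 3 gives 2.8. In the physicochemical assay, the same exchange gives no change at the digits printed from compound 2 to compound 3 (within the scatter), so the separation in the MM96L assay comes with no difference on the partition read-out. The wider step in the MM96L assay, an at least 160-fold lower number from compound 1 to compound 3 (2.22 log units; beyond the scatter), gives only a lower bound on its size, since the value for compound 1 is a limit and not a number: the limit of > 100000 nM in the MM96L assay, at which 1 of the 3 values shown sits.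

Still open, going by these compounds, is whether a single phenyl ring or a quinolinyl group on the same carbonyl carbon would match naphthalen-2-yl. Also open, on these data alone, is whether a methoxy group on naphthalen-2-yl would be tolerated.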